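Adding a Second Chloro to the Benzyl Ether

The compounds below may be only part of what the source reports. "The series", "measured", "known", "first", "only" and "open" are said of these compounds alone.

Compound 1 `Cc1ccc(NC(=S)NC(=O)c2ccc(OCc3cccc(Cl)c3Cl)cc2)cc1-c1nc2ccccc2[nH]1` – in a functional assay on SW-620 cells (Homo sapiens) for inhibition, read by MTT assay, with a stated time of 48 h (on this read-out higher numbers stand for weaker inhibition and lower numbers for stronger inhibition), compound 1 gives > 100000 nM, a limit of the assay.
Compound 2 `Cc1ccc(NC(=S)NC(=O)c2ccc(OCc3ccccc3Cl)cc2)cc1-c1nc2ccccc2[nH]1` – in this assay compound 2 gives 57100 nM.

Compound 2 holds the only finite number shown; the other value is a limit. The step from compound 3 `Cc1ccc(NC(=S)NC(=O)c2ccc(OCc3ccc(Cl)cc3Cl)cc2)cc1-c1nc2ccccc2[nH]1` back to compound 2 is chloro in place of hydrogen on an aromatic carbon. For the measured compounds named here, one measured step bears on it: an at least 1.7-fold lower number from compound 1 to compound 2 (0.24 log units; that floor lies within the scatter), which removed a chloro from a (2,3-dichlorobenzyl)oxy group and brought the value down from the limit of > 100000 nM in this assay, at which 1 of the 2 values shown sits, to a number. Putting a chloro back, now on the other side, therefore leans towards a weaker number, though the floor of that step lies within the scatter. Compound 3 is expected to give about 85000 nM, with a range from 30000 nM to 250000 nM. The expected step is a 1.5-fold higher number from compound 2 to compound 3 (0.17 log units; within the scatter).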

Compound 3, half-maximal inhibitory concentration: 57200 nM
Estimate against measurement, compound 3: 1.5-fold (0.17 log units) above, and the stated range covers the measured number.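

In this assay, a chloro on the aromatic carbon para to a large group, meta to the chloro group already present, gives a 1.0-fold higher number from compound 2 to compound 3 (0.00 log units; within the scatter), so a second chloro on the benzyl ether does not in itself separate the (2,4-dichlorobenzyl)oxy group from the (2-chlorobenzyl)oxy group. Comparing the two dichloro patterns gives an at least 1.7-fold lower number from compound 1 to compound 3 (0.24 log units; that floor lies within the scatter), so the data do not establish a difference between them either. Compound 1 holds a limit and not a number: the limit of > 100000 nM in this assay, at which 1 of the 3 values shown sits.

The compounds shown leave open whether this para position would tolerate anything other than chloro, such as a methoxy group or an amine. They also leave open how a benzyl ether carrying no chloro at all would read in this assay.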